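Chloro to methoxy: expected step from compound 3 to compound 4

A few compounds are considered here, and "the series" means these few. Any claim that something is new, unique, unknown or untested is made for them only; others in the source may bear on it.

Compound 1 `O=C1/C(=C/c2c(Cl)[nH]c3ccccc23)c2ccccc2N1Cc1ccccc1`, compound 2 `COc1c(/C=C2/C(=O)Nc3ccccc32)c2ccccc2n1-c1ccccc1` and compound 3 `COc1c(/C=C2/C(=O)Nc3ccc(Cl)cc32)c2ccccc2n1-c1ccccc1` have been measured in a functional assay on cells (Leukemia cell, Homo sapiens) for cytotoxicity, with a stated time of 48 h; on this read-out lower numbers stand for stronger inhibition of growth and higher numbers for weaker inhibition of growth. Compound 2 gives 520 nM, compound 3 gives 2340 nM and compound 1 gives 2950 nM. Compound 3 stands second highest of the three numbers; its gap to compound 1 lies within the scatter, whereas a 4.5-fold higher number from compound 2 to compound 3 (0.65 log units; beyond the scatter) lies beyond it. Compound 4 `COc1ccc2c(c1)/C(=C\c1c(OC)n(-c3ccccc3)c3ccccc13)C(=O)N2` differs from compound 3 by methoxy in place of chloro on an aromatic carbon, the group sitting meta to a fused ring and para to a fused ring. Among the measured compounds shown here, no measured step exchanges chloro for methoxy, so only the chloro-for-hydrogen step at this carbon bears on the change, and it was modest. A return part of the way toward compound 2 is expected, giving a 1.6-fold lower number from compound 3 to compound 4 (0.19 log units; within the scatter) for compound 4 in this assay. Compound 4 is thus estimated at 1500 nM, with a range of 500 nM to 4500 nM.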

Compound 4, concentration for 50% growth inhibition: 760 nM
For compound 4 the middle estimate is 2.0-fold (0.30 log units) above the measured one; the range from low to high includes it.
By their numbers in this assay, from the lowest: compounds 2 and 4 (each within the scatter of the next); then compounds 3 and 1 (each within the scatter of the next).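

At this aromatic carbon the result depends on the group: methoxy in place of chloro gives a 3.1-fold lower number from compound 3 to compound 4 (0.49 log units; beyond the scatter), so the weaker growth inhibition seen with chloro does not extend to every group here. Methoxy in place of hydrogen gives a 1.5-fold higher number from compound 2 to compound 4 (0.16 log units; within the scatter), so in this assay this carbon tolerates methoxy with no change beyond the scatter. No evidence on the cause of this difference between the groups is at hand.

Going by these compounds, whether an amine, a carboxylic acid or a longer chain at this carbon would fall with compound 2 and compound 4 or with compound 3 remains open. On these data alone, it is also open whether methoxy would have the same effect at the other carbons of this ring.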